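The source may report more compounds than this note shows. Statements on the series, on what has been measured and on what is new or still open speak of the compounds shown alone.

For the measured compounds named here, in a functional assay on MDA-MB-231 cells (Homo sapiens) for antiproliferative activity, read by MTT assay, with a stated time of 24 h (a lower number here means a stronger inhibitor, a higher number a weaker inhibitor), compound 1 (`O=C(O)CC(NS(=O)(=O)c1ccccc1)c1ccc(Cl)cc1Cl`) gives 57800 nM and compound 2 (`O=C(O)CC(NS(=O)(=O)c1cccc([N+](=O)[O-])c1)c1ccc(Cl)cc1Cl`) gives 77800 nM as the only other measured number. Compound 1 therefore stands level with compound 2, the two lying within the scatter of each other.

Compound 3 (`N#Cc1ccc(S(=O)(=O)NC(CC(=O)O)c2ccc(Cl)cc2Cl)cc1`) is still unmeasured and departs from compound 1 by one change (cyano in place of hydrogen on an aromatic carbon): cyano in place of hydrogen on an aromatic carbon, para to a large group, that is, phenyl to 4-cyanophenyl.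

Going by the values given here, the one measured step bearing on this comes from compound 2, also a single replacement of hydrogen on an aromatic carbon, there by nitro (a 1.3-fold higher number from compound 1 to compound 2 (0.13 log units; within the scatter)). It stays within the scatter. Among the compounds with values here, a single step with a different group is thin evidence, and no measured compound carries cyano. No step beyond the scatter is accordingly expected for compound 3 in this assay, in either direction.

The estimated step is small (a 1.1-fold higher number from compound 1 to compound 3 (0.03 log units; within the scatter)). Compound 3 is estimated at 62000 nM with an expected range from 33000 nM to 115000 nM for this read-out.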

Compound 3, half-maximal inhibitory concentration: 12600 nM
Compound 3: the middle estimate sits 4.9-fold (0.69 log units) above what was measured; the whole stated range lies above it.
By their numbers in this assay, from the lowest: compound 3; then compounds 1 and 2 (each within the scatter of the next).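

In this assay, for the compounds shown here, cyano in place of hydrogen on an aromatic carbon, para to a large group, gives a 4.6-fold lower number from compound 1 to compound 3 (0.66 log units; beyond the scatter) as the first step in this small set to pass beyond the scatter. This shows that replacing hydrogen on this aromatic ring can move the number in the lower direction, which the nitro replacement did not show with a 1.3-fold higher number from compound 1 to compound 2 (0.13 log units; within the scatter) as its step. The two replacements differ in the group and in where it sits on the ring, so these compounds do not separate the contribution of the group from that of its place, and no measurement here accounts for the step.

Going by these compounds, it remains open whether the lower number belongs to cyano itself or would also appear with another group at the same carbon, such as an amine, a methoxy group or a single fluorine. Also open, on these data alone, is whether cyano at another carbon of this ring, or nitro at the carbon that carries cyano in compound 3, would give a step beyond the scatter.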